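Aryl urea variation on the shared pyrazolopyrimidine-piperidine core

The source may hold more compounds than are shown below. What is called first, only, known or untested is meant among the compounds shown, and "the series" means these compounds.

Compound 2 `COc1ccc(NC(=O)NC2CCN(c3ncnc4[nH]ncc34)CC2)cc1` carries a 4-methoxyphenyl urea on the shared core. In an assay on isolated protein for inhibition of serine/threonine-protein kinase PAK 1 (Homo sapiens), read by ADP-Glo, with a stated time of 40 min (on this read-out lower numbers stand for stronger inhibition and higher numbers for weaker inhibition), compound 2 gives 6370 nM, the highest of the two numbers recorded so far. Within the data shown here, its nearest neighbour is compound 1 `Cc1cccc(C)c1NC(=O)NC1CCN(c2ncnc3[nH]ncc23)CC1`, which in this assay gives 2160 nM; the single measured step is a 2.9-fold higher number from compound 1 to compound 2 (0.47 log units; beyond the scatter), so an exchange of the aryl group has already moved the read-out beyond the scatter once.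

Compound 3 `O=C(Nc1ccc(Cl)c(Cl)c1)NC1CCN(c2ncnc3[nH]ncc23)CC1` is the next variant: 3,4-dichlorophenyl in place of 4-methoxyphenyl on an amide-type nitrogen. Among the measured compounds shown here, no measured step covers this particular exchange; the step from compound 1 to compound 2 only shows that aryl substitution pattern matters at a modest scale. Taking that as the only guide, compound 3 is expected to sit near or somewhat under compound 2, with a step of a 1.8-fold lower number from compound 2 to compound 3 (0.26 log units; within the scatter) estimated. For compound 3 the estimate in this assay is 3500 nM, with a range from 1200 nM to 10000 nM.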

Compound 3, half-maximal inhibitory concentration: 2290 nM
Compound 3: the middle estimate sits 1.5-fold (0.18 log units) above what was measured; the range from low to high includes it.
By their numbers in this assay, from the lowest: compounds 1 and 3 (each within the scatter of the next); then compound 2.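

At this amide-type nitrogen, 3,4-dichlorophenyl in place of 4-methoxyphenyl gives a 2.8-fold lower number from compound 2 to compound 3 (0.44 log units; beyond the scatter) in this assay, so the aryl group can also move the read-out beyond the scatter towards a lower number. The 3,4-dichlorophenyl and 2,6-dimethylphenyl groups do not separate, with a 1.1-fold higher number from compound 1 to compound 3 (0.03 log units; within the scatter), which leaves 4-methoxyphenyl as the only one of the three aryl groups with both of its steps beyond the scatter. Nothing available on these compounds bears on the reason for these differences.

Whether an aromatic ring is needed on this nitrogen remains open, since cyclohexyl or a plain alkyl chain lies outside the compounds shown. Also open, on these data alone, is how a phenyl carrying a single chlorine, a carboxylic acid or an amine would compare with these three aryl groups.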